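The compounds below may be only part of what the source reports. "The series", "measured", "known", "first", "only" and "open" are said of these compounds alone.

Two compounds share one core and differ only in the group on a nitrogen on an aromatic ring. In a functional assay on NCI-H1975 cells (Homo sapiens) for antiproliferative activity, read by MTT assay, with a stated time of 72 h (on this read-out lower numbers stand for stronger inhibition and higher numbers for weaker inhibition), compound 1 `C#Cc1cccc(Nc2ncnc3cc(OC)c(OCCCCC(=O)Nc4ccc(S(N)(=O)=O)cc4)cc23)c1` gives 18800 nM, while compound 2 `COc1ccc(Nc2ncnc3cc(OC)c(OCCCCC(=O)Nc4ccc(S(N)(=O)=O)cc4)cc23)cc1OC` gives 9230 nM, the lowest of the two numbers. Going by the values given here, the only measured step, a 2.0-fold lower number from compound 1 to compound 2 (0.31 log units; beyond the scatter), shows that swapping the group at this position moves the read-out modestly.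

Compound 3 `COc1cc2ncnc(Nc3cccc(C)c3)c2cc1OCCCCC(=O)Nc1ccc(S(N)(=O)=O)cc1` is not yet measured. It differs from compound 2 by 3-methylphenyl in place of 3,4-dimethoxyphenyl on a nitrogen on an aromatic ring. Among the compounds with values here, no measured pair covers this particular exchange, so the expectation rests on the one step at the same position, which was modest. A step of similar or smaller size, in either direction, seems plausible, and the estimated step is a 1.3-fold higher number from compound 2 to compound 3 (0.11 log units; within the scatter). In this assay compound 3 is therefore expected near 12000 nM, within the estimated range 4000 nM to 36000 nM.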

Compound 3, half-maximal inhibitory concentration: 32100 nM
For compound 3 the middle estimate is 2.7-fold (0.43 log units) below the measured one, within the range that was stated.
By their numbers in this assay, from the lowest: compound 2; then compounds 1 and 3 (each within the scatter of the next).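

In this assay, 3-methylphenyl in place of 3,4-dimethoxyphenyl on the nitrogen gives a 3.5-fold higher number from compound 2 to compound 3 (0.54 log units; beyond the scatter) and is the second step at this position to lie beyond the scatter, with compound 2 again holding the lower number. Methyl in place of ethynyl on an aromatic carbon gives a 1.7-fold higher number from compound 1 to compound 3 (0.23 log units; within the scatter) and so leaves compound 1 and compound 3 indistinguishable in this read-out. Among these three compounds, then, only the change to or from 3,4-dimethoxyphenyl separates the numbers.

On these data alone, whether a single methoxy group on the phenyl ring would keep the number of compound 2 stays open, as does the effect of a chloro or fluoro group there. Nothing available explains why the 3,4-dimethoxyphenyl group stands apart from the other two.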